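The compounds below may be only part of what the source reports. "The series", "measured", "known", "first", "only" and "open" are said of these compounds alone.

Compound 2 `CC(C)C(/C=C1\NC(=O)NC1=O)c1ccc(-c2ccc3cccc(F)c3c2)[nH]c1=O` is assessed in an assay on membranes from Chem-1 cells for displacement of a labelled ligand from prostaglandin E2 receptor EP3 subtype (Homo sapiens), read by scintillation counting, with a stated time of 2 h (a lower number here means a stronger inhibitor, a higher number a weaker inhibitor), where compound 2 gives 43 nM. Of the two numbers shown it is the higher one; its nearest neighbour is compound 1 `CC(C)C(c1ccc(-c2ccc3cccc(F)c3c2)[nH]c1=O)C1SC(=O)NC1=O`, which in this assay gives 25 nM, and the step of a 1.7-fold higher number from compound 1 to compound 2 (0.24 log units; within the scatter) lies within the scatter. Compound 3 `CC(C)C(CC1NC(=O)NC1=O)c1ccc(-c2ccc3cccc(F)c3c2)[nH]c1=O` has not yet been measured. It differs from compound 2 by a group of 8 heavy atoms (4 carbon, 2 nitrogen, 2 oxygen; one five-membered non-aromatic ring with 2 hetero atoms) in place of a group of 8 heavy atoms (4 carbon, 2 nitrogen, 2 oxygen; one five-membered non-aromatic ring with 2 hetero atoms), on a saturated chain carbon bound to an aromatic carbon and a saturated chain carbon. Among the measured compounds shown here, only one measured step bears on this change, and it is a different exchange of the five-membered ring itself rather than the saturation of the link to it, so it offers limited guidance; the step it shows was small. The author therefore expects compound 3 to sit near compound 2, with the step of a 1.2-fold higher number from compound 2 to compound 3 (0.07 log units; within the scatter) not clearly beyond the scatter. Compound 3 is estimated at 50 nM, in a range from 15 nM to 160 nM.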

Compound 3, inhibition constant in the prostaglandin E2 receptor EP3 subtype assay: 10 nM
Beside the measured number, compound 3's estimate is 5.0-fold (0.70 log units) above it; the measured number lies below the stated range.
By their numbers in the prostaglandin E2 receptor EP3 subtype assay, from the lowest: compound 3; then compounds 1 and 2 (each within the scatter of the next).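

In the prostaglandin E2 receptor EP3 subtype assay, saturating the link to the five-membered ring gives a 4.3-fold lower number from compound 2 to compound 3 (0.63 log units; beyond the scatter), so at this position a change outside the ring itself moves the number beyond the scatter, which the earlier ring exchange between compounds 1 and 2 did not do. The (2,5-dioxoimidazolidin-4-yl)methyl group also stands apart from 2,4-dioxo-1,3-thiazolidin-5-yl, with a 2.5-fold lower number from compound 1 to compound 3 (0.40 log units; beyond the scatter). In a physicochemical assay for solubility, in phosphate buffer, measured as kinetic solubility (on this read-out lower numbers stand for lower solubility and higher numbers for higher solubility), compound 2 gives 10700 nM and compound 3 gives 12300 nM, with a 1.1-fold higher number from compound 2 to compound 3 (0.06 log units; within the scatter), so the lower binding number comes with no solubility change beyond the scatter.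

Nothing shown here explains why saturating the link lowers the binding number. Going by these compounds, it also remains open how a longer chain in the link, or a carboxylic acid in place of the ring, would fare in the prostaglandin E2 receptor EP3 subtype assay.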